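The source may hold more compounds than are shown below. What is called first, only, known or untested is meant among the compounds shown, and "the series" means these compounds.

Within the data shown here, in a functional assay on MGC-803 cells (Homo sapiens) for inhibition, read by CCK-8 assay, with a stated time of 48 h (on this read-out lower numbers stand for stronger inhibition and higher numbers for weaker inhibition), compound 1 (`COc1ccc(CN(C(=O)CSC(=S)N2CCN(C)CC2)c2cc(OC)c(OC)c(OC)c2)cc1`) gives 1280 nM, the lowest of the three numbers measured so far. Compound 2 (`COc1ccc(CN(C(=O)CSC(=S)N2CCN(Cc3ccc(C(C)(C)C)cc3)CC2)c2cc(OC)c(OC)c(OC)c2)cc1`) gives 5390 nM, and compound 3 (`COc1ccc(CN(C(=O)CSC(=S)N2CCCc3cc(OC)ccc32)c2cc(OC)c(OC)c(OC)c2)cc1`) gives 8210 nM. Compound 4 (`COc1ccc(CN(C(=O)CN2CCN(C(C)=O)CC2)c2cc(OC)c(OC)c(OC)c2)cc1`) is still unmeasured. Its structural change is a group of 9 heavy atoms (6 carbon, 2 nitrogen, 1 oxygen; one six-membered non-aromatic ring with 2 hetero atoms) in place of a group of 10 heavy atoms (6 carbon, 2 nitrogen, 2 sulfur; one six-membered non-aromatic ring with 2 hetero atoms), on a saturated chain carbon bound to a carbonyl carbon, with 4-acetylpiperazin-1-yl as the entering group. Two measured steps offer indirect guidance: a 4.2-fold higher number from compound 1 to compound 2 (0.62 log units; beyond the scatter) and a 6.4-fold higher number from compound 1 to compound 3 (0.81 log units; beyond the scatter). Both are modest, and neither makes this exact replacement, so they support only a tentative expectation of a modest rise in this assay. The expected change is a 2.3-fold higher number from compound 1 to compound 4 (0.37 log units; beyond the scatter). For compound 4, the estimated value is 3000 nM, with an expected range of 700 nM to 12000 nM.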

Compound 4, half-maximal inhibitory concentration: 12800 nM
For compound 4 the middle estimate is 4.3-fold (0.63 log units) below the measured one; the whole stated range lies below it.
By their numbers in this assay, from the lowest: compound 1; then compounds 2, 3 and 4 (each within the scatter of the next, the first and the last beyond it).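

In this assay, 4-acetylpiperazin-1-yl entering on the saturated chain carbon bound to a carbonyl carbon gives a 10-fold higher number from compound 1 to compound 4 (1.00 log units; beyond the scatter). Unlike the earlier steps, this one removes both sulfur atoms of the leaving group, and it shows that such a replacement also raises the number. All three changes from compound 1 now point the same way, and no compound shown goes against this; nothing available explains the rise. On these data alone, this step changes the sulfur-bearing link and the acetyl together, so their separate contributions remain open. A 4-methylpiperazin-1-yl or morpholin-4-yl group on that same chain carbon would help to separate them.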